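Working notes: bromo in place of methoxy

This account rests on a few compounds, and the source may have more. Where it says the series, first, only, none or still open, it means among the compounds named here.

In a functional assay on PC-3 cells (Homo sapiens) for inhibition, read by MTT assay, with a stated time of 48 h (on this read-out lower numbers stand for stronger inhibition and higher numbers for weaker inhibition), compound 1 (`Cc1ccc(/C=C2\SC(=O)N(CCNC(=O)Nc3c(C)n(C)n(-c4ccccc4)c3=O)C2=O)cc1`) gives (58700 nM), compound 2 (`Cc1c(NC(=O)NCCN2C(=O)S/C(=C\c3ccc([N+](=O)[O-])cc3)C2=O)c(=O)n(-c2ccccc2)n1C`) gives (69300 nM) and compound 3 (`COc1ccc(/C=C2\SC(=O)N(CC(=O)Nc3c(C)n(C)n(-c4ccccc4)c3=O)C2=O)cc1`) gives (93700 nM). Compound 3 lies within the scatter of both others, so the three values set no order. Compound 4 (`Cc1c(NC(=O)CN2C(=O)S/C(=C\c3ccc(Br)cc3)C2=O)c(=O)n(-c2ccccc2)n1C`) differs from compound 3 in one place (bromo in place of methoxy on an aromatic carbon): bromo in place of methoxy on an aromatic carbon, para to a large group. For the measured compounds named here, the one measured step at an aromatic carbon, nitro in place of methyl, gave a 1.2-fold higher number from compound 1 to compound 2 (0.07 log units; within the scatter) and stands on a different linking chain from that of compound 3. On this thin evidence no step beyond the scatter is expected (a 1.2-fold lower number from compound 3 to compound 4 (0.10 log units; within the scatter)). The value estimated for compound 4 is 75000 nM (expected range 35000 nM to 150000 nM).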

Compound 4, half-maximal inhibitory concentration: 17100 nM
Compound 4: middle estimate off by 4.4-fold (0.64 log units), on the high side, and the stated range ends above it.
By their numbers in this assay, from the lowest: compound 4; then compounds 1, 2 and 3 (each within the scatter of the next).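

In this assay the change from 4-methoxyphenyl to 4-bromophenyl gives a 5.5-fold lower number from compound 3 to compound 4 (0.74 log units; beyond the scatter) on the linking chain of compound 3. This aromatic carbon, para to a large group, therefore responds to a single substitution beyond the scatter, unlike the step from methyl to nitro, a 1.2-fold higher number from compound 1 to compound 2 (0.07 log units; within the scatter) on a different chain. No available measurement explains the step. Going by these compounds, whether bromo gives a similar step on the linking chain of compound 1 remains open, as does the effect of an amine or a carboxylic acid at this position.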